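Vinyl to methyl on the ester: compound 3 to compound 4

The compounds below may be only part of what the source reports. "The series", "measured", "known", "first", "only" and "open" are said of these compounds alone.

Measured in an ADME assay on Vero cells (Chlorocebus sabaeus) for cytotoxicity, read by MTT assay, with a stated time of 48 h; a higher number here means a weaker inhibitor, a lower number a stronger inhibitor:
- compound 1 `O=C(OC1CCC(CN2CCN(c3cc(=O)c4cc(C(F)(F)F)cc([N+](=O)[O-])c4s3)CC2)CC1)c1ccccc1` gives > 64 ug/mL (a limit)
- compound 2 `CC(C)S(=O)(=O)OC1CCC(CN2CCN(c3cc(=O)c4cc(C(F)(F)F)cc([N+](=O)[O-])c4s3)CC2)CC1` gives > 64 ug/mL (a limit)
- compound 3 `C=CC(=O)OC1CCC(CN2CCN(c3cc(=O)c4cc(C(F)(F)F)cc([N+](=O)[O-])c4s3)CC2)CC1` gives > 64 ug/mL (a limit)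

Compound 3 stands at > 64 ug/mL as a limit and not a number. The whole set shows the limit of > 64 ug/mL in this assay, at which 3 of the 3 values shown sit, and so offers no number to compare. Compound 4 `CC(=O)OC1CCC(CN2CCN(c3cc(=O)c4cc(C(F)(F)F)cc([N+](=O)[O-])c4s3)CC2)CC1` differs from compound 3 in one group, with methyl in place of vinyl on a carbonyl carbon. The closest measured change is a step that the two limits leave unreadable from compound 1 to compound 3 and it gives no size to carry over. Neither a step that the two limits leave unreadable from compound 1 to compound 2 nor a step that the two limits leave unreadable from compound 2 to compound 3 gives one either. No step beyond the scatter is therefore expected, and the expected step is a step that the limit leaves unreadable from compound 3 to compound 4 in this assay. Compound 4 is estimated at 90 ug/mL with an expected range of 45 ug/mL to 180 ug/mL and is expected to be only a limit again.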

Compound 4, half-maximal inhibitory concentration: > 64 ug/mL
Compound 4: a limit, no number; the forecaster's own chance of this, stated with the estimate: 85%; the middle value is on the limit's open side.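

No step can be read between compound 1, compound 2, compound 3 and compound 4 in this assay, since each gives only a limit: the limit of > 64 ug/mL in this assay, at which 4 of the 4 values shown sit. On these data alone, whether these four compounds differ at all in this assay stays open.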